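The source may hold more compounds than are shown below. What is called first, only, known or untested is meant among the compounds shown, and "the series" means these compounds.

Measured compounds:
- compound 1 `Cc1cc(O)cc(-c2nn(CC#N)cc2-c2ccnc(-c3ccc(Oc4ccccc4)cc3)c2)c1` — in a functional assay on CCRF-CEM cells (Homo sapiens) for inhibition, read by sulforhodamine B assay, with a stated time of 48 h (on this read-out higher numbers stand for lower toxicity in this test and lower numbers for higher toxicity in this test), compound 1 gives a value that is a limit of the assay, > 100000 nM
- compound 2 `COc1cc(C)cc(-c2nn(CC#N)cc2-c2ccnc(-c3ccc(N(C)C)cc3)c2)c1` — in this assay compound 2 likewise reaches only a limit of the assay, > 100000 nM

Compound 2 thus stands at the limit of the assay rather than at a number, and the same holds for the other value shown: the limit of > 100000 nM in this assay, at which 2 of the 2 values shown sit. Compound 3 `Cc1cc(O)cc(-c2nn(CC#N)cc2-c2ccnc(-c3ccc(N(C)C)cc3)c2)c1` differs from compound 2 by one change, (hydrogen in place of methyl on an oxygen on an aromatic ring), that is, hydrogen in place of methyl on an oxygen on an aromatic ring. Among the compounds with values here, no step between measured compounds is available, and compound 1 carries the same hydroxy group without leaving the limit. The step from compound 2 to compound 3 in this assay is therefore expected to be none beyond the scatter, a step that the limit leaves unreadable from compound 2 to compound 3. Compound 3 is estimated at 150000 nM, within 60000 nM to 400000 nM, most likely reported again as a limit.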

Compound 3, concentration lethal to 50% of the cells: > 100000 nM
Compound 3 ended at the assay's limit; the forecaster's own chance of this, stated with the estimate: 85%; the middle value is on the limit's open side.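

No step can be read between compound 1, compound 2 and compound 3, because all three stand at a limit rather than at a number: the limit of > 100000 nM in this assay, at which 3 of the 3 values shown sit.

The compounds shown leave open whether methoxy to hydroxy, or dimethylamino in place of phenoxy, changes anything in this assay.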